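Iodo in Place of Trifluoromethyl: An Expected Small Step

This account rests on a few compounds, and the source may have more. Where it says the series, first, only, none or still open, it means among the compounds named here.

Of the compounds shown here, three have been measured in an ADME assay on the whole organism with Oryza sativa as the target, tested at 0.1 uM; on this read-out higher numbers stand for a weaker effect at the one concentration tested and lower numbers for a stronger effect. Compound 1 `C[C@@H](NC(=O)Nc1ccccc1C(F)(F)F)c1ccccc1` gives 99%, compound 2 `C[C@H](NC(=O)Nc1ccccc1C(F)(F)F)c1ccccc1` gives 97%, and compound 3 `CC(=O)c1ccc(NC(=O)N[C@@H](C)c2ccccc2)cc1` gives 99%. Among the compounds with values here, the only step between two compounds that differ in one place is a number 2 percentage points lower from compound 1 to compound 2 (within the scatter), a step that goes with the fact that compounds 1 and 2 differ only in the configuration as drawn. Compound 2 thus sits among three numbers that all lie within the scatter of one another, and none of the three can be called more or less active than the others.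

Compound 4 `C[C@H](NC(=O)Nc1ccccc1I)c1ccccc1` has not yet been measured. It differs from compound 2 by iodo in place of trifluoromethyl on an aromatic carbon. Within the data shown here, no measured step bears on this change: the one step known concerns configuration alone, and it was small. Among the measured compounds shown here, with nothing among the measured compounds pointing to a shift in either direction, no step beyond the scatter is expected. The estimate for compound 4 in this assay is 97%, with a range from 88% to 100%. The expected step is no change at the digits printed from compound 2 to compound 4 (within the scatter).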

Compound 4, a percentage reported as activity, at one concentration (the size of the read-out at that concentration, not a potency): 99%
Beside the measured number, compound 4's estimate is 2 percentage points below it, within the range that was stated.
By their numbers in this assay, from the lowest: compounds 2, 1, 3 and 4 (each within the scatter of the next).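

Iodo in place of trifluoromethyl on an aromatic carbon, ortho to a large group, comes with a number 2 percentage points higher from compound 2 to compound 4 (within the scatter) in this assay, and this is the only measured step that touches this position. Trifluoromethyl, with its four heavy atoms, and iodo, with its one, are therefore not told apart at this place by this read-out, so the earlier finding of no separation on configuration now has a counterpart for a change of group. No information given here bears on why the two groups are not told apart.

From the compounds shown here alone, whether an amine, a carboxylic acid or a longer chain at the same place would give a step beyond the scatter stays open. Also open, going by these compounds, is how iodo would read in the opposite configuration, that of compound 1.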